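Swapping a hydroxyethyl tail for a chlorophenyl group

This account rests on a few compounds, and the source may have more. Where it says the series, first, only, none or still open, it means among the compounds named here.

Measured compounds:
- compound 1 `CCOC(=O)c1c(C)nc(-c2ccccc2)n1OC`: in a functional assay on a cell-free system (plasma, Oryctolagus cuniculus) for inhibition, with stated times of 5 min, 1 min and 6 min (a higher number here means a weaker inhibitor, a lower number a stronger inhibitor), compound 1 reaches only a limit of the assay, > 30000 nM
- compound 2 `CCOCCOn1c(-c2cccc(C#N)c2)nc(C)c1C(=O)OCC`: in this assay compound 2 gives 6250 nM
- compound 3 `CCOC(=O)c1c(C)nc(-c2cccc(C#N)c2)n1OCCCO`: in this assay compound 3 gives 11400 nM

Among the two real numbers, compound 3 carries the higher one, and compound 2 lies a 1.8-fold higher number from compound 2 to compound 3 (0.26 log units; within the scatter) away, so the two cannot be told apart by this assay. The third value, that of compound 1, is a limit of > 30000 nM in this assay, at which 1 of the 3 values shown sits, and gives no number to compare.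

Compound 4 `CCOC(=O)c1c(C)nc(-c2cccc(C#N)c2)n1OCc1ccc(Cl)cc1` is the next step from compound 3. The change is 4-chlorophenyl in place of 2-hydroxyethyl on a saturated chain carbon bound to an oxygen on an aromatic ring. Among the measured compounds shown here, the only measured step, a 1.8-fold higher number from compound 2 to compound 3 (0.26 log units; within the scatter), traded one small oxygen-bearing tail for another and moved nothing beyond the scatter; it speaks only faintly to the present change, which exchanges a short chain for a ring. For the measured compounds named here, no measured pair here reaches from a hydroxyethyl tail to a 4-chlorophenyl group, so the direction rests on little. A modest movement is expected, with a step of a 2.3-fold lower number from compound 3 to compound 4 (0.36 log units; beyond the scatter), so compound 4 is estimated at 5000 nM in this assay, in a range from 1000 nM to 30000 nM.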

Compound 4, half-maximal inhibitory concentration: 6830 nM
Estimate against measurement, compound 4: 1.4-fold (0.14 log units) below, and the stated range covers the measured number.
By their numbers in this assay, from the lowest: compounds 2, 4 and 3 (each within the scatter of the next). At a limit, above all of these: compound 1.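

Among the compounds shown here, at this position, on a saturated chain carbon bound to an oxygen on an aromatic ring, the earlier compounds compared only two small oxygen-bearing tails, whereas compound 4 puts an aromatic ring there, and in this assay the outcome is a 1.7-fold lower number from compound 3 to compound 4 (0.22 log units; within the scatter). Measured against the ethoxymethyl group of compound 2, the 4-chlorophenyl group gives a 1.1-fold higher number from compound 2 to compound 4 (0.04 log units; within the scatter), so compounds 2, 3 and 4 cannot be told apart, even though the 2-hydroxyethyl group carries a hydrogen-bond donor and the 4-chlorophenyl group carries none. This position therefore accepts a chain with oxygen or a chlorine-bearing aromatic ring with no measurable difference in this assay, and nothing in the data shown offers a reason for that sameness.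

On these data alone, what remains open is whether any group at this position can move the number beyond the scatter, for instance an amine, a carboxylic acid or a much longer chain. As far as these compounds go, it is also open what the chlorine contributes, a question that an unsubstituted phenyl or a 4-methoxyphenyl group in the same place would address.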